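A mirror image of compound 1 awaits measurement

The source may report more compounds than this note shows. Statements on the series, on what has been measured and on what is new or still open speak of the compounds shown alone.

In a physicochemical assay for lipophilicity, using the shake flask method, in phosphate buffer, measured as octanol-water partition, at pH 7.4 (a higher number here means a more lipophilic compound, a lower number a more polar compound), compound 1 `N#CC[C@]1(n2cc(-c3nc(-c4cn[nH]c4)cn4nccc34)cn2)C[C@H](C#N)C1` gives 1.7, and compound 2 `N#CC[C@]1(n2cc(-c3nc(-c4cc[nH]n4)cn4nccc34)cn2)C[C@H](C#N)C1` gives 1.7, so the two stand level. Compound 3 `N#CC[C@]1(n2cc(-c3nc(-c4cn[nH]c4)cn4nccc34)cn2)C[C@@H](C#N)C1` has not yet been measured. Its relation to compound 1 is this: the two compounds have the same atoms and bonds and differ only in configuration as drawn: 2 of 2 stereo elements differ (all stereocentres are inverted: mirror images); a stereocentre at a saturated ring carbon is drawn r in compound 1 and s in compound 3; a stereocentre at a saturated ring carbon is drawn r in compound 1 and s in compound 3. Both stereocentres at saturated ring carbons are inverted, which makes the two compounds mirror images with the same atoms and bonds. Going by the values given here, only one measured step bears on this, and only indirectly: no change at the digits printed from compound 1 to compound 2 (within the scatter), with 1H-pyrazol-3-yl in place of 1H-pyrazol-4-yl on an aromatic carbon. Among the compounds with values here, no measured pair tests a change of configuration directly. In this assay, no shift beyond the scatter is therefore expected, and the estimated step is no change at the digits printed from compound 1 to compound 3 (within the scatter). The expectation starts from compound 1 at 1.7. Compound 3 is expected at 1.7, within an estimated range of 1.5 to 1.9.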

Compound 3, distribution coefficient: 1.6
Estimate against measurement, compound 3: 0.10 log units above; the measured number falls inside the stated range.
By their numbers in this assay, from the lowest: compounds 3, 1 and 2 (each within the scatter of the next).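

In this assay, going by these compounds alone, the pair of compound 1 and compound 3 gives the first direct reading of a change of configuration, with a number 0.10 log units lower from compound 1 to compound 3 (within the scatter). The earlier step, from compound 1 to compound 2, concerned only 1H-pyrazol-3-yl in place of 1H-pyrazol-4-yl on an aromatic carbon, and it left both stereocentres at the saturated ring carbons as drawn. In this new pair nothing leaves and nothing enters, so the step belongs to the inversion of both stereocentres alone: the fact that compounds 1 and 3 differ only in the configuration as drawn

The compounds shown leave open whether inverting only one of the two stereocentres, or both in the 1H-pyrazol-3-yl series, would also stay within the scatter. They also leave open how this assay would read with an amine or a carboxylic acid in place of a nitrile.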